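Swapping Isopropyl for Cyclopropyl on the Ring Nitrogen

The source may report more compounds than this note shows. Statements on the series, on what has been measured and on what is new or still open speak of the compounds shown alone.

- Compound 1 `COc1cccc(N2C(=O)COc3ccc(-c4cnc(OC)c(NS(=O)(=O)c5ccc(F)cc5)c4)cc32)c1` gives > 40000 nM as a limit of the assay
- Compound 2 `CC(C)N1C(=O)COc2ccc(-c3cnc(Cl)c(NS(=O)(=O)c4ccc(F)cc4)c3)cc21` gives 5380 nM as a measured number

Going by the values given here, both values come from a functional assay on HeLa cells (Homo sapiens) for antiproliferative activity, read by MTT assay, with a stated time of 72 h (on this read-out lower numbers stand for stronger inhibition and higher numbers for weaker inhibition), and only compound 2 has a true number so far, so it is the single firm reference point. Compound 3 `O=C1COc2ccc(-c3cnc(Cl)c(NS(=O)(=O)c4ccc(F)cc4)c3)cc2N1C1CC1` differs from compound 2 in one place cyclopropyl in place of isopropyl on an amide-type nitrogen in a ring with cyclopropyl in place of isopropyl on an amide-type nitrogen in a ring. Among the compounds with values here, no measured pair shows this exchange, so the forecast leans on compound 2 at 5380 nM alone. A small change of no clear direction is expected, with nothing beyond the usual scatter of this assay as the likeliest outcome. The estimated size of the change is a 1.1-fold higher number from compound 2 to compound 3 (0.05 log units; within the scatter) and no more than an expectation. For compound 3 the estimated value is 6000 nM with an expected range from 2000 nM to 20000 nM once the measurement is in.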

Compound 3, half-maximal inhibitory concentration: 7180 nM
Compound 3: the middle estimate sits 1.2-fold (0.08 log units) below what was measured; low and high end bracket the measured number.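

The exchange of isopropyl for cyclopropyl on the amide-type nitrogen, the first step shown at this position, comes out as a 1.3-fold higher number from compound 2 to compound 3 (0.13 log units; within the scatter) in this assay. Tying the open isopropyl into a three-membered ring of carbon therefore leaves the read-out within the usual scatter, so this position accepts this particular exchange with no measurable difference. No measurement shown bears on why the two groups read alike.

From the compounds shown here alone, whether a different kind of group on this nitrogen, such as a longer chain or a chain ending in an amine, would shift the number beyond the scatter stays open. Compound 1 differs from the others in more than one place, and its > 40000 nM is a limit of the assay, so it cannot settle this.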